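This account rests on a few compounds, and the source may have more. Where it says the series, first, only, none or still open, it means among the compounds named here.

In a functional assay on HepG2 cells (Homo sapiens) for antiproliferative activity, read by spectrophotometry, with a stated time of 2 days (on this read-out lower numbers stand for stronger inhibition of growth and higher numbers for weaker inhibition of growth), compound 1 `COc1ccc(Nc2ncc(C(F)(F)F)c(N3Cc4cccc(N(C)S(C)(=O)=O)c4C3)n2)cc1C(F)(F)F` gives > 30000 nM, which is a limit. Compound 2 `CN(c1cccc2c1CN(c1nc(Nc3ccc(C(F)(F)F)cc3)ncc1C(F)(F)F)C2)S(C)(=O)=O` gives > 30000 nM, also a limit. Compound 3 `Cc1cc(C)cc(Nc2ncc(C(F)(F)F)c(N3Cc4cccc(N(C)S(C)(=O)=O)c4C3)n2)c1` gives > 30000 nM, again a limit and not a number. The three stand together: the limit of > 30000 nM in this assay, at which 3 of the 3 values shown sit.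

Compound 4 `Cc1cc(Cl)ccc1Nc1ncc(C(F)(F)F)c(N2Cc3cccc(N(C)S(C)(=O)=O)c3C2)n1` carries 4-chloro-2-methylphenyl in place of 3,5-dimethylphenyl on a nitrogen on an aromatic ring.

The bearing evidence is three exchanges at that same place: a step that the two limits leave unreadable from compound 1 to compound 2, a step that the two limits leave unreadable from compound 1 to compound 3 and a step that the two limits leave unreadable from compound 2 to compound 3. None of these gives a readable size, so no step beyond the scatter, and no direction, is expected in this assay. The expected step is a number no higher from compound 3 to compound 4 (the limit leaves the size open). The estimate for compound 4 is 30000 nM, with an expected range from 12000 nM to 60000 nM.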

Compound 4, concentration for 50% growth inhibition: 19600 nM
Compound 4: the middle estimate sits 1.5-fold (0.18 log units) above what was measured, within the range that was stated.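

Among the compounds shown here, compound 4 alone gives a number rather than a limit in this assay, so 4-chloro-2-methylphenyl on a nitrogen on an aromatic ring is the only group here with a measurable reading. Going by these compounds, the steps are an at least 1.5-fold lower number from compound 3 to compound 4 (0.18 log units; that floor lies within the scatter), an at least 1.5-fold lower number from compound 2 to compound 4 (0.18 log units; that floor lies within the scatter) and an at least 1.5-fold lower number from compound 1 to compound 4 (0.18 log units; that floor lies within the scatter); each is only a floor, so the true sizes stay open. The other compounds remain at one limit: the limit of > 30000 nM in this assay, at which 3 of the 4 values shown sit.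

Open, on these data alone, is whether the chlorine or the methyl of 4-chloro-2-methylphenyl carries these steps. Also open, as far as these compounds go, is how 4-chlorophenyl, or a phenyl bearing a carboxylic acid, would read at this place.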